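Cytotoxicity of a dichlorophenoxypropanamide series on CHO cells

A few compounds are considered here, and "the series" means these few. Any claim that something is new, unique, unknown or untested is made for them only; others in the source may bear on it.

Three compounds sharing a dichlorophenoxypropanamide core have been examined in an ADME assay on CHO cells (Cricetulus griseus) for cytotoxicity, read by LDH release; a lower number here means a stronger inhibitor, a higher number a weaker inhibitor. Compound 1 `CCCC(NC(=O)C(C)Oc1ccc(Cl)cc1Cl)c1ccc(F)cc1` reaches only the limit of the assay, > 100000 nM, and so gives no number. Compound 2 `CC(Oc1ccc(Cl)cc1Cl)C(=O)NCc1ccccc1` gives 95000 nM, the highest of the two numbers available, while compound 3 `CC(Oc1ccc(Cl)cc1Cl)C(=O)NCc1ccc2cc[nH]c2c1` gives 9400 nM, a value that sits beyond the usual scatter from that of compound 2. Taken together, the values of compounds 2 and 3 show that changing the group on the chain carbon bound to the amide nitrogen can move the read-out.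

The next compound, compound 4 `CC(Oc1ccc(Cl)cc1Cl)C(=O)NCc1ccc(F)cn1`, differs from compound 2 in one place: 5-fluoropyridin-2-yl in place of phenyl on a saturated chain carbon bound to an amide-type nitrogen. Because compound 2 already gives the high number 95000 nM, a step in this assay that stays within the scatter is expected, with any drift toward a weaker number; the expected step is a 1.2-fold higher number from compound 2 to compound 4 (0.06 log units; within the scatter). Compound 4 is therefore estimated to give 110000 nM in this assay, within a range from 35000 nM to 300000 nM, with a fair chance that only a limit is reported.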

Compound 4, half-maximal inhibitory concentration: > 100000 nM
Compound 4 gave a limit, no number; the forecaster's own chance of this, stated with the estimate: 50%; the middle value is on the limit's open side.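

In this assay compound 4 gives > 100000 nM, which is a limit of the assay and not a number. The replacement of phenyl by 5-fluoropyridin-2-yl on a saturated chain carbon bound to an amide-type nitrogen can therefore be read only as an at least 1.0-fold higher number from compound 2 to compound 4 (0.02 log units; that floor lies within the scatter), so this place, where compound 2 and compound 3 differ in their read-outs, also accepts a ring with a hetero atom and a hydrogen-bond acceptor without a lower number appearing. The step has no upper bound because the read-out of compound 4 stops at the limit: the limit of > 100000 nM in this assay, at which 2 of the 4 values shown sit.

Going by these compounds, how far the true value of compound 4 lies past that limit remains open. Also open, on these data alone, is whether a dimethylamino group or a carboxylic acid on the phenyl ring of compound 2 would lower the number.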